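Chain extension at the hydroxymethyl of compound 3

The compounds below may be only part of what the source reports. "The series", "measured", "known", "first", "only" and "open" are said of these compounds alone.

Measured compounds:
- compound 1 `Cc1ccc(NC(=O)C(=O)NC(c2nc(C)c(CCO)s2)C2CCCCN2)cc1F`: > 85000 nM in an ADME assay on TZM-b1 cells (Homo sapiens) for cytotoxicity, read by XTT assay, with a stated time of 3 days; a lower number here means that less compound is tolerated, a higher number that more compound is tolerated; this value is a limit of the assay.
- compound 2 `Cc1nc(C(NC(=O)C(=O)Nc2ccc(Cl)c(F)c2)C2CCCCN2)sc1CCO`: 61000 nM in this assay.
- compound 3 `Cc1nc(C(NC(=O)C(=O)Nc2ccc(F)cc2)C2CCCCN2)sc1CO`: > 90000 nM in this assay; this value is a limit of the assay.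

Compound 3 therefore stands only at a limit, with no number of its own; the same holds for compound 1, as the limit of > 85000 nM in this assay, at which 1 of the 3 values shown sits, and the limit of > 90000 nM in this assay, at which 1 of the 3 values shown sits, show for the three values given. Among the compounds with values here, the one measured step, an at least 1.3-fold lower number from compound 1 to compound 2 (0.14 log units; that floor lies within the scatter), is a chloro in place of methyl on an aromatic carbon and lies within the scatter at its floor.

Compound 4 `Cc1nc(C(NC(=O)C(=O)Nc2ccc(F)cc2)C2CCCCN2)sc1CCO` differs from compound 3 by hydroxymethyl in place of hydroxy on a saturated chain carbon bound to an aromatic carbon; cut one bond further out this reads hydroxymethyl to 2-hydroxyethyl on the shared core. Within the data shown here, no measured step covers this change directly. Compound 1 and compound 2 already carry the 2-hydroxyethyl chain, and compound 1 sits at a limit while compound 2 gives a number close to it, so no step beyond the scatter in this assay is expected. The step of a number no higher from compound 3 to compound 4 (the limit leaves the size open) is accordingly expected to be small. Compound 4 is expected to give about 90000 nM, within 50000 nM to 150000 nM, most likely reported again as a limit.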

Compound 4, half-maximal cytotoxic concentration: > 88000 nM
Compound 4 ended at the assay's limit; the forecaster's own chance of this, stated with the estimate: 70%; the middle value lies beyond the limit too.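

Working notes on the chain: with 4-fluorophenyl on the amide-type nitrogen, neither hydroxymethyl in compound 3 nor 2-hydroxyethyl in compound 4 gives a number of its own in this assay, and compound 4 also sits at a limit of the assay: the limit of > 88000 nM in this assay, at which 1 of the 4 values shown sits.
The steps from compound 3 to compound 4 and from compound 1 to compound 4 cannot be read, as both ends of each are limits.
The one readable step is an at least 1.4-fold higher number from compound 2 to compound 4 (0.15 log units; that floor lies within the scatter) and carries 4-fluorophenyl in place of 4-chloro-3-fluorophenyl on an amide-type nitrogen, so this aromatic change is not yet shown to act beyond the scatter, and its true size stays open.

Open, going by these compounds, is whether a longer chain such as 3-hydroxypropyl, or an amine or a carboxylic acid at the end of the chain in place of the hydroxy, would bring the read-out down to a number. Also open, on these data alone, is how hydroxymethyl and 2-hydroxyethyl compare on the 4-chloro-3-fluorophenyl side, where a measured number could make the chain change readable.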